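The source may report more compounds than this note shows. Statements on the series, on what has been measured and on what is new or still open speak of the compounds shown alone.

Within the data shown here, in an assay on isolated protein for inhibition of ubiquitin carboxyl-terminal hydrolase 7 (Homo sapiens), with stated times of 30 min and 2 h (on this read-out lower numbers stand for stronger inhibition and higher numbers for weaker inhibition), compound 1 `Cn1nc2c(=O)n(CC3(O)CCN(Cc4ccc(-c5ccco5)cc4Cl)CC3)cnc2c1-c1ccc(CO)cc1` gives 42.5 nM, and compound 2 `Cn1nc2c(=O)n(CC3(O)CCN(Cc4ccc(-c5ccco5)cc4Cl)CC3)cnc2c1-c1ccc(C2(N)CC2)cc1` gives 66.1 nM; the only single-point step among the measured compounds, a 1.6-fold higher number from compound 1 to compound 2 (0.19 log units; within the scatter), lies within the scatter. Compound 3 `Cn1nc2c(=O)n(CC3(O)CCN(Cc4ccc(-c5ccncc5)cc4Cl)CC3)cnc2c1-c1ccc(CN)cc1` gives 257 nM, the highest of the three numbers, separated from compound 2 and from compound 1 by gaps beyond the scatter. Compound 4 `Cn1nc2c(=O)n(CC3(O)CCN(Cc4ccc(-c5ccsc5Cl)cc4Cl)CC3)cnc2c1-c1ccc(CN)cc1` differs from compound 3 in one place: 2-chlorothiophen-3-yl in place of pyridin-4-yl on an aromatic carbon. Among the measured compounds shown here, no measured step touches this position, and compounds 1 and 2 differ from compound 3 in two places, so nothing directly bears on the change. Compound 4 is therefore expected to stay near compound 3, with a wide band, as a 1.6-fold lower number from compound 3 to compound 4 (0.21 log units; within the scatter); its estimated value is 160 nM, from 50 nM to 500 nM.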

Compound 4, half-maximal inhibitory concentration: 453 nM
Compound 4: middle estimate off by 2.8-fold (0.45 log units), on the low side; the measured number falls inside the stated range.
By their numbers in this assay, from the lowest: compounds 1 and 2 (each within the scatter of the next); then compounds 3 and 4 (each within the scatter of the next).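

In this assay, 2-chlorothiophen-3-yl in place of pyridin-4-yl gives a 1.8-fold higher number from compound 3 to compound 4 (0.25 log units; within the scatter). Among these compounds, at this position, para to a large group and meta to a chloro group, a five-membered aromatic ring carrying chlorine and a six-membered aromatic ring containing nitrogen therefore cannot be told apart, which the earlier compounds could not show. Nothing at hand bears on why. Going by these compounds, whether a carboxylic acid, an amine or a longer chain at this position would shift the number beyond the scatter remains open.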